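The source may hold more compounds than are shown below. What is called first, only, known or untested is meant among the compounds shown, and "the series" means these compounds.

In a functional assay on HeLa cells (Homo sapiens) for cytotoxicity, read by MTT assay, with a stated time of 2 days (on this read-out higher numbers stand for weaker inhibition and lower numbers for stronger inhibition), compound 2 `Cc1cccc(-c2nc3cc(C)ccc3c(=O)[nH]2)c1` gives 11200 nM and compound 1 `Cc1ccc2nc(-c3ccccc3N(C)C)[nH]c(=O)c2c1` gives 14000 nM, two numbers within the usual scatter of each other. Compound 3 `Cc1ccc2nc(-c3cccc(C(F)(F)F)c3)[nH]c(=O)c2c1`, which carries trifluoromethyl, reports only a limit, > 50000 nM. The next structure, compound 4 `Cc1ccc2c(=O)[nH]c(-c3cccc(OC(F)(F)F)c3)nc2c1`, departs from compound 2 with trifluoromethoxy in place of methyl on an aromatic carbon, meta to a large group (trifluoromethoxy in place of methyl on an aromatic carbon). Within the data shown here, no measured step between matched compounds exists to size this change, so the expectation rests on the limit seen for compound 3 alone. A moderate step toward weaker inhibition, beyond the scatter, is expected a 2.2-fold higher number from compound 2 to compound 4 (0.35 log units; beyond the scatter). For compound 4 the estimated value in this assay is 25000 nM, with an expected range of 10000 nM to 60000 nM.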

Compound 4, half-maximal inhibitory concentration: > 50000 nM
Compound 4: a limit, no number (the forecaster's own chance of this, stated with the estimate: 35%); middle value at least 2.0-fold (0.30 log units) away from the limit.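

Among these compounds, the first matched step at this position, meta to a large group, is now sized: in this assay, trifluoromethoxy in place of methyl gives an at least 4.4-fold higher number from compound 2 to compound 4 (0.64 log units; beyond the scatter). Compound 4 reports a limit and not a number, so this step has no upper end. Compound 3, with trifluoromethyl, reports a limit too, and compound 4 now shares it: the limit of > 50000 nM in this assay, at which 2 of the 4 values shown sit.

Neither compound at the limit shows how far activity falls at this position. On these data alone, whether an amine or a hydroxyl there would stay close to compound 2 remains open.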